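A few compounds are considered here, and "the series" means these few. Any claim that something is new, unique, unknown or untested is made for them only; others in the source may bear on it.

Compound 1 `NS(=O)(=O)c1ccc(NC(=O)Nc2cccc(-c3nc(-c4ccc(NC(=O)c5cccnc5)cc4Cl)no3)c2)cc1`: > 10000 nM
Compound 2 `NS(=O)(=O)Nc1ccc(NC(=O)Nc2cccc(-c3nc(-c4ccc(NC(=O)c5cccnc5)cc4Cl)no3)c2)cc1`: 8900 nM
Compound 3 `CS(=O)(=O)Nc1ccc(NC(=O)Nc2cccc(-c3nc(-c4ccc(NC(=O)c5cccnc5)cc4Cl)no3)c2)cc1`: 600 nM

The three measured compounds share one core and differ only in the substituent on the outer phenyl ring. In a functional assay on MDA-MB-231 cells (Homo sapiens) for antiproliferative activity, read by MTT assay, with a stated time of 72 h (a higher number here means a weaker inhibitor, a lower number a stronger inhibitor), compound 1 reaches only a limit of the assay, > 10000 nM. Compound 2 gives 8900 nM in this assay, and compound 3 gives 600 nM. Compound 3 stands lowest of the numbers shown: the step of a 15-fold lower number from compound 2 to compound 3 (1.17 log units; beyond the scatter) and the step of an at least 16-fold lower number from compound 1 to compound 3 (1.22 log units; beyond the scatter) both lie beyond the scatter, whereas the step of an at least 1.1-fold lower number from compound 1 to compound 2 (0.05 log units; that floor lies within the scatter) lies within it.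

Compound 4 `CC(=O)Nc1ccc(NC(=O)Nc2cccc(-c3nc(-c4ccc(NC(=O)c5cccnc5)cc4Cl)no3)c2)cc1Br` has not been measured. It differs from compound 3 in one place: 4-acetamido-3-bromophenyl in place of 4-(methanesulfonamido)phenyl on an amide-type nitrogen. Among the measured compounds shown here, none of the measured steps covers this exchange; the one step that touches the same group, a 15-fold lower number from compound 2 to compound 3 (1.17 log units; beyond the scatter), shows that a small change on the sulfonyl group can move the number a great deal, so the uncertainty is wide. Compound 4 is estimated at 1500 nM, within 300 nM to 8000 nM. The estimated step is a 2.5-fold higher number from compound 3 to compound 4 (0.40 log units; beyond the scatter).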

Compound 4, half-maximal inhibitory concentration: 1000 nM
Compound 4: the middle estimate sits 1.5-fold (0.18 log units) above what was measured; measured number inside the range.
By their numbers in this assay, from the lowest: compounds 3 and 4 (each within the scatter of the next); then compound 2. At a limit, above all of these: compound 1.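

Putting 4-acetamido-3-bromophenyl in place of 4-(methanesulfonamido)phenyl on the amide-type nitrogen gives a 1.7-fold higher number from compound 3 to compound 4 (0.22 log units; within the scatter) in this assay, so this position keeps compound 3's level of activity with a group that holds no sulfur, which the sulfur-bearing earlier compounds could not show. The same exchange set against the sulfamoylamino group gives an 8.9-fold lower number from compound 2 to compound 4 (0.95 log units; beyond the scatter), so the sulfonamide-type compounds do not all sit on one side of the new group. Set against the sulfamoyl group, it gives an at least 10-fold lower number from compound 1 to compound 4 (1.00 log units; beyond the scatter), and this step is only a floor, as compound 1 stands at a limit: the limit of > 10000 nM in this assay, at which 1 of the 4 values shown sits.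

Acetamido and bromine enter together, so the compounds shown do not separate what each contributes. As far as these compounds go, whether a fluorine or a methyl could stand in for the bromine, or a free amine for the acetamido, remains open.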